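The compounds below may be only part of what the source reports. "The series", "measured", "known", "first", "only" and "open" are said of these compounds alone.

Compound 1 (`CCCOc1ccc(C(O)C2OC(=O)c3c(OC)cc(OC)cc32)cc1`), compound 2 (`CCCCOc1ccc(C(O)C2OC(=O)c3c(OC)cc(OC)cc32)cc1`) and compound 3 (`COc1cc(OC)c2c(c1)C(C(O)c1ccc(OCc3ccc(Br)cc3)cc1)OC2=O`) share one core. In an ADME assay on RAW264.7 cells (Mus musculus) for cytotoxicity, read by MTT assay, with a stated time of 24 h, in the absence of a further agent (on this read-out lower numbers stand for stronger inhibition and higher numbers for weaker inhibition), compound 1 gives > 40000 nM, which is a limit and not a number. In this assay compound 2 gives > 40000 nM, also a limit. In this assay compound 3 gives > 40000 nM, again a limit. Within the data shown here, compound 3 therefore stands level with the other two only in the sense that none of them has an exact number, and the whole series so far comes down to one observation: the limit of > 40000 nM in this assay, at which 3 of the 3 values shown sit.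

Compound 4 (`COc1cc(OC)c2c(c1)C(C(O)c1ccc(OCc3ccc(C#N)cc3)cc1)OC2=O`) differs from compound 3 by one small change: cyano in place of bromo on an aromatic carbon. In words, this is cyano in place of bromo on an aromatic carbon, para to a large group, so that 4-bromobenzyl becomes 4-cyanobenzyl.

Among the measured compounds shown here, no measured step makes this exact change. The nearest are a step that the two limits leave unreadable from compound 1 to compound 3 and a step that the two limits leave unreadable from compound 2 to compound 3, which bring in the 4-bromophenyl group, and a step that the two limits leave unreadable from compound 1 to compound 2, which extends the chain. None of these has a readable size. With the limit of > 40000 nM in this assay, at which 3 of the 3 values shown sit, no step beyond the scatter is expected in this assay, and a reading at the same limit is the likeliest outcome. The expected change is a step that the limit leaves unreadable from compound 3 to compound 4. For compound 4 the estimate is 50000 nM, with an expected range from 25000 nM to 100000 nM.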

Compound 4, half-maximal inhibitory concentration: > 40000 nM
Compound 4 ended at the assay's limit; the forecaster's own chance of this, stated with the estimate: 85%; the middle value is on the limit's open side.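

In this assay compound 4 gives > 40000 nM, which is a limit and not a number. No step from compound 1, compound 2 or compound 3 to compound 4 can be read, because every value is the same limit: the limit of > 40000 nM in this assay, at which 4 of the 4 values shown sit.

The compounds shown leave open what exact value any of the four has, and so whether cyano or bromo makes any difference in this assay.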